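Series notes: benzyloxy in place of bromo

The source may hold more compounds than are shown below. What is called first, only, known or untested is meant among the compounds shown, and "the series" means these compounds.

Compound 2 `COc1ccc(C2=NN(C(=O)c3ccc(C)nc3)C(c3ccc(Br)cc3)C2)cc1` gives 4280 nM in a functional assay on WM 266-4 cells (Homo sapiens) for antiproliferative activity, read by MTT assay, with a stated time of 24 h (on this read-out higher numbers stand for weaker inhibition of growth and lower numbers for stronger inhibition of growth), and compound 1 `COc1ccc(C2=NN(C(=O)c3cncc(Br)c3)C(c3ccc(Br)cc3)C2)cc1` gives 5630 nM in this assay. The step of a 1.3-fold lower number from compound 1 to compound 2 (0.12 log units; within the scatter) concerns 6-methylpyridin-3-yl in place of 5-bromopyridin-3-yl on the carbonyl carbon and lies within the scatter, so compound 2 holds the lower of the two numbers without standing apart from compound 1. Compound 3 `COc1ccc(C2=NN(C(=O)c3ccc(C)nc3)C(c3ccc(OCc4ccccc4)cc3)C2)cc1`, not yet measured, differs from compound 2 by benzyloxy in place of bromo on an aromatic carbon, on an aromatic carbon of a six-membered aromatic ring of carbon only, para to a large group. Among the compounds with values here, no measured step touches that aromatic carbon; the only measured step changes the carbonyl side. There is therefore no basis for expecting a shift beyond the scatter in either direction in this assay, and the expected step of a 1.1-fold lower number from compound 2 to compound 3 (0.03 log units; within the scatter) is set near zero with a wide range. Compound 3 is estimated at 4000 nM, between 1300 nM and 12000 nM.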

Compound 3, concentration for 50% growth inhibition: 7950 nM
Compound 3: middle estimate off by 2.0-fold (0.30 log units), on the low side; the measured number falls inside the stated range.
By their numbers in this assay, from the lowest: compounds 2, 1 and 3 (each within the scatter of the next).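

At the aromatic carbon para to a large group, the first measured change is benzyloxy in place of bromo, which gives a 1.9-fold higher number from compound 2 to compound 3 (0.27 log units; within the scatter) in this assay and so does not separate the two groups on this read-out. This position therefore carries either a single bromine or a group with its own six-membered aromatic ring of carbon only, with no step beyond the scatter, whereas the earlier step spoke only for the carbonyl side. No measurement at hand bears on this result.

From the compounds shown here alone, whether an amine or a carboxylic acid on this aromatic carbon would move the number beyond the scatter remains open. Also open, going by these compounds, is whether benzyloxy gives a similar step when 5-bromopyridin-3-yl sits on the carbonyl carbon.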